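Swapping a phenyl for a hydroxymethyl-furan on the core

The source may hold more compounds than are shown below. What is called first, only, known or untested is meant among the compounds shown, and "the series" means these compounds.

Of the compounds shown here, two from this series have been tested. Compound 1 `O=C(c1ccc(F)cc1)c1cccc(/C=c2\[nH]c(=O)/c(=C/c3c[nH]cn3)[nH]c2=O)c1` gives 278 nM in a functional assay on NCI-H460 cells (Homo sapiens) for cytotoxicity, read by MTT assay, with a stated time of 72 h; a lower number here means a stronger inhibitor, a higher number a weaker inhibitor. Going by the values given here, compound 2 `O=c1[nH]/c(=C\c2cccc(Oc3ccc(F)cc3)c2)c(=O)[nH]/c1=C\c1ccccc1` gives 389 nM in this assay; its value and that of compound 1 lie within the usual scatter of each other, so neither stands apart, and compound 2 simply sits at the same level as its only neighbour. Compound 3 `O=c1[nH]/c(=C\c2ccc(CO)o2)c(=O)[nH]/c1=C\c1cccc(Oc2ccc(F)cc2)c1` has not been measured yet. It differs from compound 2 in one place: 5-(hydroxymethyl)furan-2-yl in place of phenyl on a double-bonded chain carbon bound to an aromatic carbon. Among the compounds with values here, because the two measured values, 278 nM for compound 1 and 389 nM for compound 2, sit so close, there is no measured step to lean on. The change is expected to move the number by no more than the scatter, in either direction, so the estimated step of a 1.1-fold lower number from compound 2 to compound 3 (0.05 log units; within the scatter) is small. Compound 3 is estimated at 350 nM, with a likely range from 120 nM to 1100 nM.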

Compound 3, half-maximal inhibitory concentration: 41.5 nM
The estimate for compound 3 lay 8.4-fold (0.93 log units) above the measured number; the measured number lies below the stated range.
By their numbers in this assay, from the lowest: compound 3; then compounds 1 and 2 (each within the scatter of the next).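

In this assay, putting 5-(hydroxymethyl)furan-2-yl in place of phenyl on a double-bonded chain carbon bound to an aromatic carbon gives a 9.4-fold lower number from compound 2 to compound 3 (0.97 log units; beyond the scatter), so this position can respond clearly to a change of group. The swap alters more than one feature at once: a six-membered aromatic ring of carbon only gives way to a five-membered aromatic ring with 1 hetero atom, and a hydroxymethyl group with hydrogen-bond donor and acceptor counts enters where phenyl has none. Nothing available here explains why the number falls.

The compounds shown leave open whether the furan ring, the hydroxymethyl group or the two together account for the step. A furan carrying an amine or a carboxylic acid instead of the hydroxymethyl group would help separate these contributions.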